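The compounds below may be only part of what the source reports. "The series", "measured", "known", "first", "only" and "open" are said of these compounds alone.

Three compounds sharing one core were taken into a functional assay on the whole organism (strain albino) with Mus musculus as the target, with a stated time of 0.5 h; on this read-out lower numbers stand for an effect already at smaller amounts and higher numbers for an effect only at larger amounts of compound. Among the measured compounds shown here, compound 1 (`COc1ccc(C2CC(Nc3nc4ccc([N+](=O)[O-])cc4s3)=NN2C(C)=O)cc1`) gives 149 umol/kg, the only number. Compound 2 (`CC(=O)N1N=C(Nc2nc3ccccc3s2)CC1c1ccccc1`) has the entry "not determined" (no result reported), and compound 3 (`CC(=O)N1N=C(Nc2nc3ccccc3s2)CC1c1ccc(Cl)cc1`) has the entry "not determined" (no result reported). Compound 3 therefore has no place on the numerical scale of this assay, and neither does compound 2.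

Compound 4 (`CC(=O)N1N=C(Nc2nc3ccc([N+](=O)[O-])cc3s2)CC1c1ccc(Cl)cc1`) follows from compound 3 by one change: nitro in place of hydrogen on an aromatic carbon, a nitro in place of hydrogen on an aromatic carbon. This gives compound 4 the nitro that compound 1 also carries, though the two compounds are not otherwise identical.

Without a number for compound 3, the size and direction of this step in this assay cannot be read from the data. For the measured compounds named here, the only anchor is compound 1 at 149 umol/kg, so compound 4 is expected to differ from that level by no more than the usual scatter. For compound 4 the estimated value is 140 umol/kg, with an expected range from 50 umol/kg to 400 umol/kg.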

Compound 4, dose for half-maximal effect: 138 umol/kg
For compound 4 the middle estimate is 1.0-fold (0.01 log units) above the measured one, within the range that was stated.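

In this assay, the series now holds its first readable comparison between compounds that differ in one place: with the nitro kept, chloro in place of methoxy on an aromatic carbon gives a 1.1-fold lower number from compound 1 to compound 4 (0.03 log units; within the scatter). At this place, the two groups therefore cannot be told apart on this read-out. The step that brings the nitro into compound 4 cannot be read, so what the nitro contributes remains unknown, and no measurement at hand gives a reason for the result.

The compounds shown leave open whether a group of a different kind at that aromatic carbon, such as an amine or a carboxylic acid, would also stay level with compound 1 and compound 4. They also leave open how an amine in place of the nitro would read out.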